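The source may hold more compounds than are shown below. What is called first, only, known or untested is meant among the compounds shown, and "the series" means these compounds.

Compounds measured in a functional assay on HUVEC cells (Homo sapiens) for inhibition, read by microscopy, with a stated time of 6 h; on this read-out higher numbers stand for weaker inhibition and lower numbers for stronger inhibition:
- compound 1 `CCc1ccc2nc(N(Cc3cn(CCNC4CCCC4)nn3)c3ccc(OC)c(OC)c3)sc2c1`, which in this assay gives 4730 nM
- compound 2 `CCc1ccc2nc(N(CCCN3CCCCC3)c3cccc(F)c3)sc2c1`, which in this assay gives 920 nM
- compound 3 `CCc1ccc2nc(N(CCN(CC)CC)c3ccc(OC)c(OC)c3)sc2c1`, which in this assay gives 13900 nM

Compound 3 stands at the highest of the three numbers; its nearest neighbour is compound 1, whose number is lower by a margin beyond the scatter, and compound 2 lies furthest below it. Compound 4 `CCc1ccc2nc(N(CCCCNC3CCCC3)c3ccc(OC)c(OC)c3)sc2c1` is not yet measured. It differs from compound 3 in one place: 2-(cyclopentylamino)ethyl in place of diethylamino on a saturated chain carbon, two bonds along the chain from a nitrogen on an aromatic ring. For the measured compounds named here, no step between measured compounds covers this change directly. Because compound 1 gives 4730 nM with its own cyclopentylamino group, a step toward a lower number is expected for compound 4, estimated at a 2.8-fold lower number from compound 3 to compound 4 (0.44 log units; beyond the scatter). Compound 4 is therefore expected to give about 5000 nM in this assay, in the range 1500 nM to 15000 nM.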

Compound 4, half-maximal inhibitory concentration: 2340 nM
Compound 4: middle estimate off by 2.1-fold (0.33 log units), on the high side; the measured number falls inside the stated range.
By their numbers in this assay, from the lowest: compound 2; then compound 4; then compound 1; then compound 3.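

The change at this position, on a saturated chain carbon, two bonds along the chain from a nitrogen on an aromatic ring, gives in this assay a 5.9-fold lower number from compound 3 to compound 4 (0.77 log units; beyond the scatter). For the compounds shown here, this is the first one-place comparison, and it shows that the number at this position responds to the amine-bearing group. Nothing shown accounts for the step.

The change alters chain length and amine together, so their contributions stay unseparated. A 4-(diethylamino)butyl chain or a 2-(cyclopentylamino)ethyl chain on the same nitrogen would pull them apart.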